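Swapping a fluorophenyl for a pyridyl on the piperidine carbon

The source may report more compounds than this note shows. Statements on the series, on what has been measured and on what is new or still open speak of the compounds shown alone.

Three compounds built around an amide attached to a saturated nitrogen-containing ring carry different aromatic groups on that carbon. Compound 1 `CN1CCCC(NC(=O)c2ccc(C(F)(F)F)cc2C#N)(c2ccccc2)C1` is the odd one out: in an assay on cells for inhibition of sodium- and chloride-dependent glycine transporter 1 (Homo sapiens) (on this read-out lower numbers stand for an effect already at smaller amounts and higher numbers for an effect only at larger amounts of compound), compound 1 reaches only the limit > 10000 nM, which is a boundary of the test rather than a number. Compound 2 `COc1ccc(C2(NC(=O)c3c(OC)cc(C(F)(F)F)cc3SC)CCCN(C)C2)cc1` gives 170 nM in this assay. Compound 3 `COc1cc(C(F)(F)F)cc(SC)c1C(=O)NC1(c2cccc(F)c2)CCCN(C)C1` gives 48 nM in this assay, the lowest of the two numbers shown; the only measured step, a 3.5-fold lower number from compound 2 to compound 3 (0.55 log units; beyond the scatter), separates it from compound 2.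

Compound 4 `COc1cc(C(F)(F)F)cc(SC)c1C(=O)NC1(c2cccnc2)CCCN(C)C1` keeps the core of compound 3 and changes the aromatic group once more: pyridin-3-yl in place of 3-fluorophenyl on a saturated ring carbon. Among the measured compounds shown here, no measured step covers this exact swap; the nearest comparison, a 3.5-fold lower number from compound 2 to compound 3 (0.55 log units; beyond the scatter), shows that exchanging one aromatic group for another at this position shifted the number by a modest amount. A similar modest shift, here towards a somewhat higher number, is therefore expected, namely a 2.1-fold higher number from compound 3 to compound 4 (0.32 log units; beyond the scatter). On that basis compound 4 is estimated to give about 100 nM in this assay, with a plausible range from 30 nM to 400 nM.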

Compound 4, half-maximal effective concentration: 54 nM
Beside the measured number, compound 4's estimate is 1.9-fold (0.27 log units) above it, within the range that was stated.
By their numbers in this assay, from the lowest: compounds 3 and 4 (each within the scatter of the next); then compound 2. At a limit, above all of these: compound 1.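

In this assay, exchanging the aromatic group on the saturated ring carbon gives a 1.1-fold higher number from compound 3 to compound 4 (0.05 log units; within the scatter), so 3-fluorophenyl and pyridin-3-yl cannot be told apart on this read-out, although pyridin-3-yl carries a hydrogen-bond acceptor and 3-fluorophenyl carries none. Among the compounds shown here, the only exchange read earlier at this carbon had moved the number beyond the scatter, so this is the first sign that a change of aromatic group here can leave the number in place. For the compounds shown here, the comparison with 4-methoxyphenyl gives a 3.1-fold lower number from compound 2 to compound 4 (0.50 log units; beyond the scatter), which places pyridin-3-yl on the same side of compound 2 as 3-fluorophenyl and leaves 4-methoxyphenyl as the one group of these three that stands apart.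

Nothing measured here bears on why these two groups give matching numbers. Going by these compounds alone, with only three aromatic groups compared on this carbon, it stays open how a pyridin-4-yl, a 3-chlorophenyl or a non-aromatic cyclohexyl group would compare, and whether an amine or a carboxylic acid placed on the pyridine ring would keep the number where it is.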